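Iodo in place of hydroxy on compound 2

A few compounds are considered here, and "the series" means these few. Any claim that something is new, unique, unknown or untested is made for them only; others in the source may bear on it.

Of the compounds shown here, two carry numbers so far in a functional assay on PC-3 cells (Homo sapiens), read by wound healing assay, with a stated time of 24 h (on this read-out lower numbers stand for stronger inhibition and higher numbers for weaker inhibition), and they sit apart. Compound 1 (`O=C1NC(=O)/C(=C/c2cccc(-c3cccs3)n2)N1`) gives 30800000 nM on this read-out. Compound 2 (`O=C1NC(=O)/C(=C/c2cc(O)c[nH]2)N1`) gives 10100000 nM as the lowest of the two numbers, and its gap to compound 1 lies beyond the scatter. For the measured compounds named here, these two compounds differ in more than one place, so no measured step isolates a single change.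

Compound 3 (`O=C1NC(=O)/C(=C/c2cc(I)c[nH]2)N1`) keeps the core of compound 2 and carries iodo in place of hydroxy on an aromatic carbon, two ring bonds from the ring nitrogen. The counted change is iodo in place of hydroxy on an aromatic carbon in full. Going by the values given here, with no measured pair to calibrate this swap, the expectation starts from compound 2 at 10100000 nM and leaves wide margins on both sides. The expected step of a 1.3-fold lower number from compound 2 to compound 3 (0.10 log units; within the scatter) is estimated to stay within the scatter, with no firm direction. Compound 3 is estimated at 8000000 nM with an expected range from 2000000 nM to 30000000 nM in this assay once measured.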

Compound 3, half-maximal inhibitory concentration: 5020000 nM
Compound 3: the middle estimate sits 1.6-fold (0.20 log units) above what was measured; low and high end bracket the measured number.
By their numbers in this assay, from the lowest: compounds 3 and 2 (each within the scatter of the next); then compound 1.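

In this assay, for the compounds shown here, iodo in place of hydroxy on an aromatic carbon, two ring bonds from the ring nitrogen, gives a 2.0-fold lower number from compound 2 to compound 3 (0.30 log units; within the scatter) and is the first single-place step available. At this position, therefore, a group counted with 1 hydrogen-bond donor and 1 hydrogen-bond acceptor and a group counted with neither read alike within the scatter, so this one swap gives no sign that the read-out depends on the donor and acceptor of hydroxy. No supporting measurement accompanies this step to account for its size.

The compounds shown do not say whether an amine, a carboxylic acid, a methoxy group or a longer chain on the same aromatic carbon would stay within the scatter of compound 2 and compound 3 or move beyond it. Going by these compounds alone, compound 1 differs from both of them in more than one place, so no single-place step connects it to this pair, and whether the hydroxy-to-iodo result carries over to other parts of the series remains open.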